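Moving the Acid Out onto a Two-Carbon Chain

The source may report more compounds than this note shows. Statements on the series, on what has been measured and on what is new or still open speak of the compounds shown alone.

Compound 1 `O=C(O)c1cccc(NC(=O)C(C2CCCCC2)n2c(-c3ccc(Cl)cc3)nc3cc(F)c(F)cc32)c1`: 14% in a functional assay for agonist activity at Bile acid receptor (Homo sapiens), read by a luciferase reporter; a higher number here means a larger maximal response, a lower number a smaller maximal response
Compound 2 `O=C(O)c1ccc(NC(=O)[C@H](C2CCCCC2)n2c(-c3ccc(Cl)cc3)nc3cc(F)c(F)cc32)c(C(F)(F)F)c1`: 59% in this assay

Compound 1 stands lowest of the two numbers, with compound 2 well beyond the scatter above it. Compound 3 `O=C(O)CCc1ccc(NC(=O)C(C2CCCCC2)n2c(-c3ccc(Cl)cc3)nc3cc(F)c(F)cc32)cc1` has not been measured; it differs from compound 1 by 4-(2-carboxyethyl)phenyl in place of 3-carboxyphenyl on an amide-type nitrogen. Among the measured compounds shown here, no measured pair shows this change, so its size in this assay is uncertain, though the higher reading of compound 2 , 59%, suggests an upward direction. Compound 3 is expected to give 35%, within 10% to 65%. The expected step is a number 21 percentage points higher from compound 1 to compound 3 (beyond the scatter), a modest rise.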

Compound 3, largest response reached (reported as efficacy), in percent of the reference or control that the assay uses: 18%
The estimate for compound 3 lay 17 percentage points above the measured number; the measured number falls inside the stated range.
By their numbers in this assay, from the lowest: compounds 1 and 3 (each within the scatter of the next); then compound 2.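

In this assay, 4-(2-carboxyethyl)phenyl in place of 3-carboxyphenyl on an amide-type nitrogen gives a number 4 percentage points higher from compound 1 to compound 3 (within the scatter). This position therefore accepts the larger group, with its acid carried out on a chain, but the readings of the two compounds cannot be told apart. Nothing available explains this result.

On these data alone, both the place of the acid on the ring and the chain differ in this one swap, so their separate contributions remain unknown. A longer chain ending in the carboxylic acid, or an amine in place of the acid, remains an open question at this position.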